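A few compounds are considered here, and "the series" means these few. Any claim that something is new, unique, unknown or untested is made for them only; others in the source may bear on it.

Measured in a functional assay on NCI/ADR-RES cells (Homo sapiens) for antiproliferative activity, read by sulforhodamine B assay, with a stated time of 48 h; on this read-out higher numbers stand for weaker inhibition of growth and lower numbers for stronger inhibition of growth:
compound 1 `CCCCCC[C@@H](O)C/C=C\CCCCCCCC(=O)N1CCOCC1` gives 29.4 ug/mL
compound 2 `CCCCCCCC/C=C\CCCCCCCC(=O)N1CCCCC1` gives 7.7 ug/mL

Compound 2 has the lower number of the two, and its gap to compound 1 lies beyond the scatter, so it is the stronger growth inhibitor of this pair. Among the measured compounds shown here, the two compounds differ in more than one place, so no single-change step is available in this assay. Next is compound 3 `CCCCCCCC/C=C\CCCCCCCC(=O)N1CCOCC1`, which differs from compound 2 by one change: morpholin-4-yl in place of piperidin-1-yl on a carbonyl carbon. For the measured compounds named here, the only guide to this change is indirect. Compound 1 at 29.4 ug/mL also carries morpholin-4-yl on a carbonyl carbon and has the higher number, but its gap to compound 2 cannot be assigned to that group alone. A modest move towards a higher number, meaning weaker growth inhibition, is therefore expected, and it may not exceed the scatter. The expected change is a 1.6-fold higher number from compound 2 to compound 3 (0.19 log units; within the scatter). The estimated value for compound 3 is 12 ug/mL, with an expected range from 5 ug/mL to 30 ug/mL.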

Compound 3, concentration for 50% growth inhibition: 3.3 ug/mL
Estimate against measurement, compound 3: 3.6-fold (0.56 log units) above; measured number outside the range, below it.
By their numbers in this assay, from the lowest: compound 3; then compound 2; then compound 1.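

In this assay, morpholin-4-yl in place of piperidin-1-yl on a carbonyl carbon gives a 2.3-fold lower number from compound 2 to compound 3 (0.37 log units; beyond the scatter), so at this carbonyl carbon morpholin-4-yl goes with the stronger inhibition of growth, and compound 3 is the strongest growth inhibitor of the three. The high number of compound 1 therefore cannot be read as a penalty of morpholin-4-yl: with that group held constant, hydrogen in place of hydroxy on a saturated chain carbon bound to two saturated chain carbons gives an 8.9-fold lower number from compound 1 to compound 3 (0.95 log units; beyond the scatter), and this is the larger of the two steps. No measurement at hand offers an explanation for either step.

As far as these compounds go, each step rests on a single pair, so it remains open whether morpholin-4-yl would keep its edge over piperidin-1-yl in a chain carrying hydroxy, and whether hydroxy would cost as much on a piperidin-1-yl compound. Also open, from the compounds shown here alone, is how other groups on the carbonyl carbon, such as a dimethylamino group or a free carboxylic acid, or a shorter or longer chain, would compare with compound 3.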